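Methyl added to the hydroxyethyl side chain of compound 2

The source may hold more compounds than are shown below. What is called first, only, known or untested is meant among the compounds shown, and "the series" means these compounds.

Measured so far:
compound 1, `COc1ccc(C(=O)Nc2ncc(Cc3cccc(C(F)(F)F)c3)s2)cc1OCC(=O)O`, in an assay on microsomes for inhibition of acyl-CoA desaturase 1 (Mus musculus), with a stated time of 60 min (a higher number here means a weaker inhibitor, a lower number a stronger inhibitor), a limit of the assay only: > 9990 nM
compound 2, `COc1ccc(C(=O)Nc2ncc(Cc3cccc(C(F)(F)F)c3)s2)cc1OCC(C)O`, in this assay: 2170 nM

Going by the values given here, compound 2 holds the only numerical value shown in this assay; the other entry is a limit, namely (the limit of > 9990 nM in this assay, at which 1 of the 2 values shown sits). Among the compounds with values here, the step between them, an at least 4.6-fold lower number from compound 1 to compound 2 (0.66 log units; beyond the scatter), is the only measured step and concerns a different change: 1-hydroxyethyl in place of carboxy on a saturated chain carbon bound to an oxygen on an aromatic ring.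

Compound 3, `COc1ccc(C(=O)Nc2ncc(Cc3cccc(C(F)(F)F)c3)s2)cc1OCC(C)(C)O`, differs from compound 2 by methyl in place of hydrogen on a saturated chain carbon bound to an oxygen on a saturated carbon and two saturated chain carbons. Within the data shown here, no measured step touches this kind of change, so the one step available gives little guidance on size or direction. The expectation for compound 3 in this assay is therefore a step within the usual scatter, a 1.1-fold lower number from compound 2 to compound 3 (0.06 log units; within the scatter). Compound 3 is estimated at 1900 nM, with a range from 600 nM to 6500 nM.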

Compound 3, half-maximal inhibitory concentration: > 9990 nM
Compound 3 ended at the assay's limit (the forecaster's own chance of this, stated with the estimate: 12%); middle value at least 5.2-fold (0.72 log units) away from the limit.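

The side chain of compound 2 turns out to be sensitive to one added methyl: in this assay, going from 2-hydroxypropoxy to 2-hydroxy-2-methylpropoxy gives an at least 4.6-fold higher number from compound 2 to compound 3 (0.66 log units; beyond the scatter). The earlier step at this side chain concerned only the replacement of carboxy, and this one shows that keeping the hydroxy group does not by itself keep a measurable number, as compound 3 carries that hydroxy group and still reads only as a limit. Compound 1 and compound 3 are both limits, so the step between them cannot be read, and the two stand together at the end of the scale: the limit of > 9990 nM in this assay, at which 2 of the 3 values shown sit.

Going by these compounds, how far the added methyl really moves the number stays open, as the result for compound 3 gives only a bound on the step. Whether this sensitivity is particular to methyl also remains unsettled, and an ethyl, a methoxy or an amine on the same saturated chain carbon, or a longer chain carrying the hydroxy group, would be needed to test it.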